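Two Swaps on a Diaryl Urea and an Expected Fall

This account rests on a few compounds, and the source may have more. Where it says the series, first, only, none or still open, it means among the compounds named here.

Compound 1 `O=C(Nc1ccc(Oc2ccc(-c3nccs3)cc2)cc1)Nc1cc(Br)cc(C(F)(F)F)c1` is the anchor of this small set. In a functional assay on A549 cells (Homo sapiens) for inhibition, read by MTT assay and WST assay, with a stated time of 72 h, tested at 10 uM (on this read-out higher numbers stand for more inhibition of growth at the one concentration tested and lower numbers for less inhibition of growth), compound 1 gives 81.7%. Two changes are made from it, each in one place. Compound 2 `O=C(Nc1ccc(Oc2ccc(-c3nccs3)cc2)cc1)Nc1ccc(F)c(Cl)c1` carries 3-chloro-4-fluorophenyl in place of 3-bromo-5-(trifluoromethyl)phenyl on an amide-type nitrogen and in this assay compound 2 gives 37.3%, so that a number 44.4 percentage points lower from compound 1 to compound 2 (beyond the scatter). Compound 3 `O=C(Nc1ccc(Oc2ccc(-c3ncc[nH]3)cc2)cc1)Nc1cc(Br)cc(C(F)(F)F)c1` instead carries 1H-imidazol-2-yl in place of 1,3-thiazol-2-yl on an aromatic carbon, and in this assay compound 3 gives 44.1%, so that a number 37.6 percentage points lower from compound 1 to compound 3 (beyond the scatter). The numbers of compound 2 and compound 3 lie within the scatter of each other, so no order between them can be read.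

Compound 4 `O=C(Nc1ccc(Oc2ccc(-c3ncc[nH]3)cc2)cc1)Nc1ccc(F)c(Cl)c1` has not been measured. For the measured compounds named here, it differs from compound 3 by 3-chloro-4-fluorophenyl in place of 3-bromo-5-(trifluoromethyl)phenyl on an amide-type nitrogen, which is the same change as the one from compound 1 to compound 2, made on the other core; the two cores differ by 1H-imidazol-2-yl in place of 1,3-thiazol-2-yl on an aromatic carbon. Going by the values given here, the only guide to the size of the step is a number 44.4 percentage points lower from compound 1 to compound 2 (beyond the scatter). Compound 3 starts from a lower number than compound 1, so the same drop cannot be carried over in full. The read-out cannot fall much below no inhibition at all. The step from compound 3 to compound 4 is expected to be a number 29.1 percentage points lower from compound 3 to compound 4 (beyond the scatter). For compound 4 the expected number is 15%, with a range from 0% to 40%.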

Compound 4, percent growth inhibition at one concentration: 14.6%
Beside the measured number, compound 4's estimate is 0.4 percentage points above it, within the range that was stated.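

In this assay the change to 3-chloro-4-fluorophenyl on the amide-type nitrogen again lowers the read-out, giving a number 29.5 percentage points lower from compound 3 to compound 4 (beyond the scatter) on the second core, so its direction carries over but its size does not: the same change on two cores in this assay, a number 44.4 percentage points lower (beyond the scatter) from compound 1 to compound 2 and a number 29.5 percentage points lower (beyond the scatter) from compound 3 to compound 4, 14.9 percentage points apart, beyond the scatter of two such steps.

Read the other way round, 1H-imidazol-2-yl in place of 1,3-thiazol-2-yl also lowers the read-out on both partners, giving a number 22.7 percentage points lower from compound 2 to compound 4 (beyond the scatter) when the aryl group is 3-chloro-4-fluorophenyl, and its size also differs: the same change on two cores in this assay, a number 37.6 percentage points lower (beyond the scatter) from compound 1 to compound 3 and a number 22.7 percentage points lower (beyond the scatter) from compound 2 to compound 4, 14.9 percentage points apart, beyond the scatter of two such steps.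

These two gaps come from the same four compounds, so they are one finding seen from two sides: the two changes do not simply add up in percentage points, though these four compounds do not show why, nor whether the direction would hold on any further core.

Going by these compounds, what stays open is how other groups would behave at the same two places, such as an unsubstituted phenyl or a 3-(trifluoromethyl)phenyl on the amide-type nitrogen, or an oxazol-2-yl or a carboxylic acid in place of the 1,3-thiazol-2-yl. A read-out at one concentration also leaves open how these compounds would compare across a range of concentrations.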